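The source may report more compounds than this note shows. Statements on the series, on what has been measured and on what is new or still open speak of the compounds shown alone.

Working notes on the series. Of the compounds shown here, two have been measured in a functional assay on WHCO1 cells (Homo sapiens) for cytotoxicity, read by MTT assay, with a stated time of 24 h (a higher number here means a weaker inhibitor, a lower number a stronger inhibitor), so far. Compound 1 `CC(C)=CC(O)C1=CC(=O)c2ccccc2C1=O` in this assay gives 5200 nM. Compound 2 `CC(O)C1=CC(=O)c2ccccc2C1=O` in this assay gives 6400 nM. The only step between them, a 1.2-fold higher number from compound 1 to compound 2 (0.09 log units; within the scatter), is within the scatter, so the two numbers stand level with each other and compound 2 has compound 1 as its nearest and only neighbour on the numbers shown.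

Compound 3 `C=CC(O)C1=CC(=O)c2ccccc2C1=O` has not yet been measured in this assay. Relative to compound 2 the change is vinyl in place of methyl on a saturated chain carbon bound to a double-bonded ring carbon and an oxygen on a saturated carbon. Among the measured compounds shown here, the one measured step that bears on this position is the exchange of 2-methylprop-1-en-1-yl for methyl at the same saturated chain carbon, and that step, a 1.2-fold higher number from compound 1 to compound 2 (0.09 log units; within the scatter), stayed within the scatter. Vinyl is a smaller alkenyl chain at the same place, so a step of similar, unremarkable size is expected, with no direction claimed beyond the scatter: a 1.1-fold lower number from compound 2 to compound 3 (0.04 log units; within the scatter) is the expected step from compound 2 to compound 3. On that basis compound 3 is estimated at 5800 nM in this assay, with a range from 2500 nM to 13000 nM.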

Compound 3, half-maximal inhibitory concentration: 4300 nM
The estimate for compound 3 lay 1.3-fold (0.13 log units) above the measured number, within the range that was stated.
By their numbers in this assay, from the lowest: compounds 3, 1 and 2 (each within the scatter of the next).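

In this assay, with a 1.5-fold lower number from compound 2 to compound 3 (0.17 log units; within the scatter) and a 1.2-fold lower number from compound 1 to compound 3 (0.08 log units; within the scatter), methyl, vinyl and 2-methylprop-1-en-1-yl all stand level on the saturated chain carbon bound to a double-bonded ring carbon and an oxygen on a saturated carbon. Among the compounds shown here, earlier, only one exchange at this carbon could be read; there are now three, and none leaves the scatter, so neither adding a double bond outside aromatic rings to methyl nor exchanging vinyl for the longer alkenyl group separates one compound from another on these numbers. Nothing shown gives a reason why the three stand level, and no measurement beyond these cytotoxicity numbers bears on the result.

As far as these compounds go, the three compounds cover only small carbon-only groups at this carbon, so it remains open whether an amine, a carboxylic acid, a phenyl ring or a longer saturated chain there would produce a step beyond the scatter. Also open, from the compounds shown here alone, is whether the level numbers hold when the hydroxyl on that carbon is exchanged for a methoxy group or a ketone, or when the shared core is changed.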